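Swapping the aryl group on the amine nitrogen of compound 1

The compounds below may be only part of what the source reports. "The series", "measured", "known", "first", "only" and "open" are said of these compounds alone.

Among the measured compounds shown here, compound 1 `Cc1nc(C(=O)N2CC3(CC3)C[C@H]2CNc2ncc(Cl)cn2)c(-c2ccccc2)s1` is one of two compounds measured in a functional assay on CHO cells for antagonist activity at Orexin/Hypocretin receptor type 1 (Homo sapiens), read by FLIPR and calcium flux (a lower number here means a less potent compound, a higher number a more potent compound, by a factor of ten per unit of this negative logarithm), and in it compound 1 gives 6.8, the lower of the two numbers. The other measured compound, compound 2 `Cc1ccc(-n2nccn2)c(C(=O)N2CCC3(CC3)C[C@H]2CNc2cccc(C)n2)c1`, shares no single-point relationship with compound 1 and differs from it in several parts of the structure; in this assay compound 2 gives 8.2, which is beyond the scatter above compound 1. Compound 3 `Cc1nc(C(=O)N2CC3(CC3)C[C@H]2CNc2cc(C(F)(F)F)ccn2)c(-c2ccccc2)s1` is not yet measured and is reached from compound 1 by a single change, (4-(trifluoromethyl)pyridin-2-yl in place of 5-chloropyrimidin-2-yl on an amine nitrogen). Cut one bond further out, the change reads (5-chloropyrimidin-2-yl)amino to (4-(trifluoromethyl)pyridin-2-yl)amino. For the measured compounds named here, no measured pair in this set shows this particular change, so its size is not known from the data. A moderate step upward is expected for compound 3, with a number 0.40 log units higher from compound 1 to compound 3 (beyond the scatter) from compound 1, though a result within the scatter of compound 1 would also not be surprising. In this assay compound 3 is estimated at 7.2, expected to fall between 6.5 and 7.9.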

Compound 3, negative logarithm of the antagonist equilibrium constant: 8.2
Estimate against measurement, compound 3: 1.00 log units below; measured number above the stated range.
By their numbers in this assay, from the lowest: compound 1; then compounds 2 and 3 (each within the scatter of the next).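

Among the compounds shown here, putting 4-(trifluoromethyl)pyridin-2-yl in place of 5-chloropyrimidin-2-yl on the amine nitrogen gives a number 1.40 log units higher from compound 1 to compound 3 (beyond the scatter) in this assay and so shows, for the first time in this set, that this position responds strongly to the aryl group it carries while the rest of compound 1 stays the same. For the compounds shown here, the single pair changes several things at once, since the entering ring has one hetero atom where the leaving ring has two, and it carries trifluoromethyl where the other carries chlorine. Nothing at hand bears on why the number rises, so no cause can be given for it.

Which of these differences carries the step remains open, and a pyrimidine ring bearing trifluoromethyl, or a pyridine ring bearing chlorine, would divide them. From the compounds shown here alone, it is also open whether a nitrile or a methoxy group in place of the trifluoromethyl would hold the gain, and whether the same exchange would give a step of similar size on a different core.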